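This account rests on a few compounds, and the source may have more. Where it says the series, first, only, none or still open, it means among the compounds named here.

Of the compounds shown here, three built on a shared core have been measured in a functional assay on COLO 205 cells (Homo sapiens) for cytotoxicity, read by MTT assay, with a stated time of 72 h; on this read-out higher numbers stand for weaker inhibition and lower numbers for stronger inhibition. Compound 1 `COc1cc(/C=C/C(=O)Nc2cc(C(=O)c3cc(OC)c(OC)c(OC)c3)ccc2OC)ccc1F` gives 11800 nM, compound 2 `COc1ccc(C(=O)c2cc(OC)c(OC)c(OC)c2)cc1NC(=O)/C=C/c1ccc(F)c(F)c1` gives 6020 nM, and compound 3 `COc1ccc(/C=C/C(=O)Nc2cc(C(=O)c3cc(OC)c(OC)c(OC)c3)cc(OC)c2OC)cc1` gives 4800 nM. Compound 3 thus carries the lowest of the three numbers, although its gap to compound 2 lies within the scatter; only its gap to compound 1 lies beyond it. Compound 4 `COc1cc(C(=O)c2cc(OC)c(OC)c(OC)c2)cc(NC(=O)/C=C/c2cc(F)c(F)c(F)c2)c1OC` differs from compound 3 in one place: 3,4,5-trifluorophenyl in place of 4-methoxyphenyl on a double-bonded chain carbon bound to a double-bonded chain carbon. Among the compounds with values here, the one measured step that bears on this change, a 2.0-fold lower number from compound 1 to compound 2 (0.29 log units; within the scatter), also put fluorine where methoxy stood and stayed within the scatter. Compound 4 is therefore expected to show a modestly lower number, a 1.4-fold lower number from compound 3 to compound 4 (0.14 log units; within the scatter), a step that may well stay within the scatter. Compound 4 in this assay is estimated at 3500 nM, ranging from 1500 nM to 8000 nM.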

Compound 4, half-maximal inhibitory concentration: 4300 nM
Compound 4: the middle estimate sits 1.2-fold (0.09 log units) below what was measured, and the stated range covers the measured number.
By their numbers in this assay, from the lowest: compounds 4, 3, 2 and 1 (each within the scatter of the next, the first and the last beyond it).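

The step of a 1.1-fold lower number from compound 3 to compound 4 (0.05 log units; within the scatter) in this assay shows that, on the core of compound 3, 3,4,5-trifluorophenyl can stand in place of 4-methoxyphenyl with no change that can be read. Thus, at this position, the loss of the methoxy group and the entry of three fluorines leave the number within the scatter. Nothing available bears on why the two groups read alike. Going by these compounds, whether an amine or a carboxylic acid in place of these groups would move the number beyond the scatter remains open.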